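The source may hold more compounds than are shown below. What is called first, only, known or untested is meant among the compounds shown, and "the series" means these compounds.

Compound 1, with the structure `O=C(NNC(=S)Nc1ccccc1F)c1cc([N+](=O)[O-])c[nH]1`, is one of three compounds tested in an ADME assay on Vero cells (Chlorocebus sabaeus) for cytotoxicity, read by MTT assay, with a stated time of 72 h (on this read-out lower numbers stand for stronger inhibition and higher numbers for weaker inhibition), where compound 1 gives 471000 nM. Compound 2, with the structure `Cc1ccccc1NC(=S)NNC(=O)c1cc([N+](=O)[O-])cn1C`, gives 471000 nM in this assay, level with compound 1 at the digits shown, so that the two stand together at the top of the three numbers. Compound 3, with the structure `Cn1cc([N+](=O)[O-])cc1C(=O)NNC(=S)Nc1ccccc1F`, gives 293000 nM, and the change a 1.6-fold lower number from compound 1 to compound 3 (0.21 log units; within the scatter) is within the scatter, as is the change a 1.6-fold lower number from compound 2 to compound 3 (0.21 log units; within the scatter).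

Compound 4, with the structure `O=C(NNC(=S)Nc1ccc(Cl)cc1)c1cc([N+](=O)[O-])c[nH]1`, differs from compound 1 in one place: 4-chlorophenyl in place of 2-fluorophenyl on an amide-type nitrogen. Among the measured compounds shown here, neither measured step touches the same position in the same way; the only step on the phenyl ring, from compound 2 to compound 3, was within the scatter, and the change on the aromatic nitrogen, from compound 1 to compound 3, was also within the scatter. A step of no more than the scatter is therefore expected from compound 1 to compound 4 in this assay, namely a 1.0-fold lower number from compound 1 to compound 4 (0.02 log units; within the scatter). Compound 4 is accordingly estimated to give 450000 nM, expected to fall between 200000 nM and 1000000 nM.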

Compound 4, half-maximal inhibitory concentration: 191000 nM
For compound 4 the middle estimate is 2.4-fold (0.37 log units) above the measured one, outside the stated range (below it).
By their numbers in this assay, from the lowest: compounds 4, 3, 1 and 2 (each within the scatter of the next, the first and the last beyond it).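

In this assay, 4-chlorophenyl in place of 2-fluorophenyl on the amide-type nitrogen gives (a 2.5-fold lower number from compound 1 to compound 4 (0.39 log units; beyond the scatter)), the first step among these compounds to go beyond the scatter. The group on this nitrogen is therefore a place where the number can move, even though the earlier changes, fluoro in place of methyl on an aromatic carbon and methyl in place of hydrogen on an aromatic nitrogen, stayed within the scatter. The two groups match in heavy-atom count, hydrogen-bond donors, acceptors and charge, and no measurement here explains the difference.

The halogen and its printed position change together in this step, so the compounds shown cannot tell which of the two matters. Also open, from the compounds shown here alone, is how a phenyl ring carrying an amine or a carboxylic acid would behave on this nitrogen.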